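Swapping the aryl group on sulfur in a nucleoside analogue

This account rests on a few compounds, and the source may have more. Where it says the series, first, only, none or still open, it means among the compounds named here.

Measured so far:
- compound 1 `O=[N+]([O-])c1cccc2c1CCN(c1ncnc3c1ncn3[C@@H]1O[C@H](CO)[C@@H](O)[C@H]1O)C2`: 3020 nM
- compound 2 `CCC(C)Sc1nc(N)nc2c1ncn2[C@@H]1O[C@H](CO)[C@@H](O)[C@H]1O`: 63100 nM
- compound 3 `OC[C@H]1O[C@@H](n2cnc3c(CSc4ccccc4Br)ncnc32)[C@H](O)[C@@H]1O`: 2400 nM

In an assay on isolated protein for binding affinity to Equilibrative nucleoside transporter 1 (Homo sapiens) (a lower number here means a stronger inhibitor, a higher number a weaker inhibitor), compound 3 gives the lowest of the three numbers. Compound 1 sits closest, and that gap is within the scatter, so the two cannot be ranked against each other; compound 2 is far weaker, beyond the scatter.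

Compound 4 `CC(C)(C)c1ccc(SCc2ncnc3c2ncn3[C@@H]2O[C@H](CO)[C@@H](O)[C@H]2O)cc1` keeps the shared core and the sulfur link of compound 3 and differs in one place: 4-(tert-butyl)phenyl in place of 2-bromophenyl on a sulfur. Among the compounds with values here, no measured pair shows this change, so the direction is uncertain; the step of a 1.0-fold higher number from compound 3 to compound 4 (0.02 log units; within the scatter) is expected to stay within the scatter. Compound 4 is estimated at 2500 nM, with a range from 600 nM to 10000 nM.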

Compound 4, half-maximal inhibitory concentration: 331000 nM
The estimate for compound 4 lay 130-fold (2.12 log units) below the measured number; measured number outside the range, above it.
By their numbers in this assay, from the lowest: compounds 3 and 1 (each within the scatter of the next); then compound 2; then compound 4.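

The sulfur substituent is far from a neutral spot: in this assay, 4-(tert-butyl)phenyl in place of 2-bromophenyl gives a 140-fold higher number from compound 3 to compound 4 (2.14 log units; beyond the scatter), although each group holds one six-membered aromatic ring of carbon only and neither has hydrogen-bond donors or acceptors. The number at this position therefore depends strongly on which aryl group sits there, even with the shared core and sulfur link unchanged. Nothing measured here explains the size of this step.

Going by these compounds, whether the bromine, the tert-butyl group or the place of each on the ring drives the step stays open. Within the data shown here, a plain phenyl on the same sulfur would give a first point of comparison for both groups.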